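A few compounds are considered here, and "the series" means these few. Any claim that something is new, unique, unknown or untested is made for them only; others in the source may bear on it.

- compound 1 `O=C(c1cncc(Br)c1)N1N=C(c2ccc(Cl)cc2)CC1c1ccc(OCc2ccccc2)cc1` 8130 nM
- compound 2 `Cc1ccc(C(=O)N2N=C(c3ccc(Cl)cc3)CC2c2ccc(OCc3ccccc3)cc2)cn1` 9200 nM

Within the data shown here, in a functional assay on WM 266-4 cells (Homo sapiens) for antiproliferative activity, read by MTT assay, with a stated time of 24 h (a lower number here means a stronger inhibitor of growth, a higher number a weaker inhibitor of growth), compound 1 gives 8130 nM and stands level with compound 2, the only other measured compound: a 1.1-fold higher number from compound 1 to compound 2 (0.05 log units; within the scatter) is all that separates them.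

Compound 3 `O=C(c1cncc(Br)c1)N1N=C(c2ccc(Cl)cc2)CC1c1ccc(Br)cc1` keeps the 5-bromopyridin-3-yl group of compound 1 but has bromo in place of benzyloxy on an aromatic carbon, para to a large group (bromo in place of benzyloxy on an aromatic carbon). Among the measured compounds shown here, the one measured step, a 1.1-fold higher number from compound 1 to compound 2 (0.05 log units; within the scatter), lies on the carbonyl carbon, at a different place, so it bears on this change only weakly. No measurement shows what removing the benzyloxy does, and none settles the direction. The estimated step is a 1.4-fold higher number from compound 1 to compound 3 (0.13 log units; within the scatter) with no shift beyond the scatter expected in this assay and a wide range left open. Compound 3 is estimated at 11000 nM (expected range 3500 nM to 35000 nM).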

Compound 3, concentration for 50% growth inhibition: 8010 nM
The estimate for compound 3 lay 1.4-fold (0.14 log units) above the measured number; the range from low to high includes it.
By their numbers in this assay, from the lowest: compounds 3, 1 and 2 (each within the scatter of the next).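

In this assay, bromo in place of benzyloxy on an aromatic carbon, para to a large group, gives a 1.0-fold lower number from compound 1 to compound 3 (0.01 log units; within the scatter), so this much smaller group leaves the number unchanged within the scatter. For this pair, then, the benzyloxy with its six-membered aromatic ring is not required for growth inhibition of this size, and this position tolerates the loss of all but a single bromine atom. Nothing measured here offers an explanation for this result.

Neither change shown, at the carbonyl carbon or at this position, moves the number beyond the scatter, so what would do so remains open. Also open, on these data alone, is whether an amine, a carboxylic acid or a longer alkoxy chain at this position would shift the number, and whether bromo there would behave alike with the 6-methylpyridin-3-yl group of compound 2.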